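Halogen swap on the triazole aryl and liver cell toxicity

A few compounds are considered here, and "the series" means these few. Any claim that something is new, unique, unknown or untested is made for them only; others in the source may bear on it.

Three sulfonamides built on a shared core were tested in an ADME assay on L02 cells (Homo sapiens) for cytotoxicity, read by MTT assay, with a stated time of 24 h; on this read-out higher numbers stand for lower toxicity in this test and lower numbers for higher toxicity in this test. Compound 1 `Cc1ccccc1-n1cc(-c2cccc(NS(=O)(=O)c3c[nH]c(=O)[nH]c3=O)c2)nn1` gives 15300 nM. Compound 2 `O=c1[nH]cc(S(=O)(=O)Nc2cccc(-c3cn(-c4cccc(F)c4)nn3)c2)c(=O)[nH]1` gives "not toxic" (no number reported) in this assay, with no number attached to that result. Compound 3 `O=c1[nH]cc(S(=O)(=O)Nc2cccc(-c3cn(-c4ccc(F)cc4)nn3)c2)c(=O)[nH]1` likewise gives "not toxic" (no number reported) in this assay, again without a figure. Going by the values given here, compound 3 therefore stands without a single number in this assay, and it shares that position with one other entry, compound 2; only compound 1 carries a measured concentration, and no step between any two of these measured compounds can be counted, since no pair differs in one place.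

Compound 4 `O=c1[nH]cc(S(=O)(=O)Nc2cccc(-c3cn(-c4cccc(Cl)c4)nn3)c2)c(=O)[nH]1` has not yet been measured. It differs from compound 3 by 3-chlorophenyl in place of 4-fluorophenyl on an aromatic nitrogen. Among the compounds with values here, with no counted step available, no direction beyond the usual scatter can be claimed for this change in this assay; the two described members without numbers and the one measured value of compound 1 point to low toxicity across the set. Compound 4 is expected to show about 40000 nM in this assay, with a range of 10000 nM to 150000 nM, and it is estimated that the result may again come back as a qualitative report rather than a number.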

Compound 4, half-maximal cytotoxic concentration: 8330 nM
Estimate against measurement, compound 4: 4.8-fold (0.68 log units) above; measured number below the stated range.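

With compound 4, the group on the aromatic nitrogen of the five-membered ring carries a second measured number, and in this assay the change to 3-chlorophenyl from 2-methylphenyl gives a 1.8-fold lower number from compound 1 to compound 4 (0.26 log units; within the scatter), so these two groups cannot be told apart in this test. Compound 3 and compound 2 carry only the report "not toxic", whereas compound 4 gives 8330 nM, which shows that a member with a halogen on this phenyl can return a concentration, though the size of the change from 4-fluorophenyl or from the fluorine of compound 2 cannot be read without numbers for those compounds. Nothing available speaks to the reason for this result.

The compounds shown leave open whether a bromine, a methoxy group or an amine on this phenyl would give a number like those of compound 1 and compound 4 or a report like that of compound 3. They also leave open how a carboxylic acid on this phenyl would read in this assay at this same place on the ring.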